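Halogen swap on the amino-bearing core

The source may hold more compounds than are shown below. What is called first, only, known or untested is meant among the compounds shown, and "the series" means these compounds.

Measured compounds:
compound 1 `CCCCN1CCC(CNC(=O)c2cc(Br)cc3[nH]cnc23)CC1`: 0.64 nM
compound 2 `CCCCN1CCC(CNC(=O)c2cc(Br)c([N+](=O)[O-])c3[nH]cnc23)CC1`: 48.2 nM
compound 3 `CCCCN1CCC(CNC(=O)c2cc(Cl)c(N)c3[nH]cnc23)CC1`: 22.4 nM

In an assay on membranes from striatum for binding affinity to 5-hydroxytryptamine receptor 4 (Rattus norvegicus) (a lower number here means a stronger inhibitor, a higher number a weaker inhibitor), compound 3 gives 22.4 nM, the second highest of the three numbers. Compound 2 gives 48.2 nM, a higher number beyond the scatter, while compound 1 gives 0.64 nM, a far lower number. Compound 4 `CCCCN1CCC(CNC(=O)c2cc(Br)c(N)c3[nH]cnc23)CC1` differs from compound 3 by bromo in place of chloro on an aromatic carbon. Among the compounds with values here, no measured step covers this exchange of one halogen for another; the only measured step, a 75-fold higher number from compound 1 to compound 2 (1.88 log units; beyond the scatter), concerns a nitro group and does not bear on it. The expectation is therefore no step beyond the scatter: a 1.2-fold lower number from compound 3 to compound 4 (0.09 log units; within the scatter). For compound 4 the estimated value in this assay is 18 nM, with a range from 6 nM to 60 nM.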

Compound 4, inhibition constant: 27.8 nM
For compound 4 the middle estimate is 1.5-fold (0.19 log units) below the measured one, within the range that was stated.
By their numbers in this assay, from the lowest: compound 1; then compounds 3, 4 and 2 (each within the scatter of the next, the first and the last beyond it).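

In this assay, bromo in place of chloro on an aromatic carbon ortho to an amino group leaves the number within the scatter (a 1.2-fold higher number from compound 3 to compound 4 (0.09 log units; within the scatter)). With bromo held, amino in place of nitro also stays within the scatter (a 1.7-fold lower number from compound 2 to compound 4 (0.24 log units; within the scatter)), whereas amino in place of hydrogen gives a large step (a 43-fold higher number from compound 1 to compound 4 (1.64 log units; beyond the scatter)), so amino and nitro both stand far from compound 1 in this series. No available evidence accounts for these steps.

Still open, as far as these compounds go, is whether a methyl or hydroxyl group on the carbon carrying the amino group stays as far from compound 1. Also open, from the compounds shown here alone, is whether chloro matches bromo without that amino group.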